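Bridged Diamine Replaces Oxetanyl Piperazine on Shared Core

The compounds below may be only part of what the source reports. "The series", "measured", "known", "first", "only" and "open" are said of these compounds alone.

Measured so far:
compound 1, `CN(C[C@H]1Cc2c(cccc2N2CCN(C3COC3)CC2)CN1)[C@H]1CCCc2cccnc21`, 381 nM
compound 2, `FC1(F)CCC(CN(C[C@H]2Cc3c(cccc3N3CCNCC3)CN2)[C@H]2CCCc3cccnc32)CC1`, 498 nM

In a functional assay on CCRF-CEM cells for antagonist activity at C-X-C chemokine receptor type 4 (Homo sapiens), read by calcium flux, with stated times of 25 min and 90 s (a lower number here means a stronger inhibitor, a higher number a weaker inhibitor), compound 1 gives 381 nM, the lower of the two numbers recorded here. Its nearest neighbour, compound 2, gives 498 nM in this assay, and the gap between these two values lies within the usual scatter of repeated measurements, so the pair shows no real separation.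

The unmeasured compound 3, `CN(C[C@H]1Cc2c(cccc2N2C[C@H]3C[C@@H]2CN3)CN1)[C@H]1CCCc2cccnc21`, keeps the core of compound 1 and differs from it at one place: a group of 7 heavy atoms (5 carbon, 2 nitrogen; 2 five-membered non-aromatic rings with 1 hetero atom each) in place of a group of 10 heavy atoms (7 carbon, 2 nitrogen, 1 oxygen; one four-membered non-aromatic ring with 1 hetero atom, one six-membered non-aromatic ring with 2 hetero atoms), on an aromatic carbon. For the measured compounds named here, no pair of measured compounds differing at a single place is available, so the size of this step cannot be read from earlier measurements. With both measured compounds sitting close together in this assay, a step from compound 1 to compound 3 of no more than the scatter is expected, with a slight lean towards a lower number, which is the expected step of a 1.3-fold lower number from compound 1 to compound 3 (0.10 log units; within the scatter). Compound 3 is therefore estimated at 300 nM in this assay, in a range from 100 nM to 900 nM.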

Compound 3, half-maximal inhibitory concentration: 20.7 nM
Compound 3: middle estimate off by 14-fold (1.16 log units), on the high side; measured number outside the range, below it.
By their numbers in this assay, from the lowest: compound 3; then compounds 1 and 2 (each within the scatter of the next).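

In this assay, the group on this aromatic carbon turns out to have a strong bearing on the number, which compounds 1 and 2 could not show, as they differ in more than one place. Replacing 4-(oxetan-3-yl)piperazin-1-yl with the smaller group of two five-membered non-aromatic rings gives an 18-fold lower number from compound 1 to compound 3 (1.26 log units; beyond the scatter), so this position is far from indifferent to what it carries. The swap changes several things at once, removing the oxygen, adding a hydrogen-bond donor and bringing in two defined stereocentres, and no measurement here bears on why the step is so large.

The compounds shown leave open which of these differences carries the step, and whether a plain piperazin-1-yl group, with its free amine and no oxetane, would on the core of compound 1 already give much of it. They also leave open whether the mirror-image form of the entering group, or a simple open-chain diamine such as an aminoethylamino group, would do the same, and whether the entering group would have a similar effect alongside the difluorocyclohexylmethyl group of compound 2.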